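The source may hold more compounds than are shown below. What is called first, only, known or untested is meant among the compounds shown, and "the series" means these compounds.

Working notes on the series in an assay for inhibition of 15-hydroxyprostaglandin dehydrogenase [NAD(+)] (Homo sapiens), read by fluorescence, with a stated time of 15 min, in the presence of a further agent that is not named here; a lower number here means a stronger inhibitor, a higher number a weaker inhibitor.

Within the data shown here, compound 1 `CCOC(=O)c1sc2nc(-c3cccs3)cc(-c3ccccc3)c2c1N` is the starting point, and in this assay compound 1 gives only a limit, > 7500 nM; this is the limit at which one of the three values so far sits (the limit of > 7500 nM in this assay, at which 1 of the 3 values shown sits).

Two further compounds are measured. Compound 2 `CCCC[S+]([O-])c1sc2nc(-c3nccs3)cc(-c3ccc(CNC(=O)NCC)cc3)c2c1N` gives 2.1 nM in this assay. Compound 3 `CCCC[S+]([O-])c1sc2nc(-c3nccs3)cc(-c3ccc(CNC(C)=O)cc3)c2c1N` gives 2.5 nM. Among the measured compounds shown here, the single one-place step among them, a 1.2-fold higher number from compound 2 to compound 3 (0.08 log units; within the scatter), concerns a carbonyl substituent remote from the shared core and is within the scatter. For the measured compounds named here, both differ from compound 1 in several places at once, so no measured step bears directly on the change considered next.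

Compound 4 `CCCCS(=O)(=O)c1sc2nc(-c3cccs3)cc(-c3ccccc3)c2c1N` differs from compound 1 by butylsulfonyl in place of ethoxycarbonyl on an aromatic carbon. Going by the values given here, the only measured step is silent on this position, so no direction can be drawn from it; compound 1 itself is known only as a limit. A step of an at least 12-fold lower number from compound 1 to compound 4 (1.09 log units; beyond the scatter) is estimated, and compound 4 is expected to give about 600 nM, within 60 nM to 6000 nM, with a real chance that only a limit is again reported.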

Compound 4, half-maximal inhibitory concentration: 25 nM
Compound 4: middle estimate off by 24-fold (1.38 log units), on the high side; the measured number lies below the stated range.
By their numbers in this assay, from the lowest: compounds 2 and 3 (each within the scatter of the next); then compound 4. At a limit, above all of these: compound 1.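

In this assay, among these compounds, butylsulfonyl in place of ethoxycarbonyl on the aromatic carbon next to the ring sulfur gives an at least 300-fold lower number from compound 1 to compound 4 (2.47 log units; beyond the scatter) and is the first measured step at this position. With the rest of the core of compound 1 unchanged, this single change is enough to turn a reading that is only a limit into a measured number. The size of the step is a bound and not an exact figure, since the value for compound 1 is a limit: the limit of > 7500 nM in this assay, at which 1 of the 4 values shown sits.

Going by these compounds, whether the drop belongs to the sulfonyl or to the butyl chain stays open; a methylsulfonyl or a butyl ester on the same core would separate the two. Steps from compound 4 to compound 2 or compound 3 cannot be read, as these differ in several places, so it is also open whether the change carries over to them.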